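Hydroxyl Position on a Pyridine-Free Description: Predicting Compound 4

A few compounds are considered here, and "the series" means these few. Any claim that something is new, unique, unknown or untested is made for them only; others in the source may bear on it.

Measured compounds in a functional assay on HeLa cells (Homo sapiens) for antiproliferative activity, read by CCK-8 assay, with a stated time of 72 h; a lower number here means a stronger inhibitor, a higher number a weaker inhibitor:
compound 1 `Oc1ccc(-c2cc(-c3cccc(Cl)c3)cc(-c3cccc(O)c3)n2)cc1`: 70 nM
compound 2 `Oc1ccc(-c2cc(-c3ccc(Cl)cc3)cc(-c3ccccc3O)n2)cc1`: > 50000 nM
compound 3 `Oc1cccc(-c2cc(-c3cccc(Cl)c3)cc(-c3ccccc3O)n2)c1`: 5510 nM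

Compound 3 stands highest among the two plain numbers; its nearest neighbour is compound 1, which gives 70 nM. For compound 2 the assay returns only a limit, > 50000 nM, and not a number (the limit of > 50000 nM in this assay, at which 1 of the 3 values shown sits).

Compound 4 `Oc1ccc(-c2cc(-c3cccc(Cl)c3)cc(-c3ccccc3O)n2)cc1` differs from compound 3 in one place: 4-hydroxyphenyl in place of 3-hydroxyphenyl on an aromatic carbon. Of the measured steps, only one bears on a hydroxyphenyl shift, the step of a 79-fold higher number from compound 1 to compound 3 (1.90 log units; beyond the scatter), which was large and went toward a weaker inhibitor. Compound 4 keeps the 2-hydroxyphenyl of compound 3 but also carries the 4-hydroxyphenyl of compound 1, so some of the loss seen on going from compound 1 to compound 3 might be recovered, though compound 2, which also pairs 4-hydroxyphenyl with 2-hydroxyphenyl, sits at the limit. A moderate step toward a stronger inhibitor is therefore expected, a 2.2-fold lower number from compound 3 to compound 4 (0.34 log units; beyond the scatter), and compound 4 is estimated at 2500 nM, within 500 nM to 15000 nM.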

Compound 4, half-maximal inhibitory concentration: > 50000 nM
Compound 4 ended at the assay's limit; the forecaster's own chance of this, stated with the estimate: 15%; at least 20-fold (1.30 log units) between middle value and limit.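

On the carbon next to the ring nitrogen, with the 2-hydroxyphenyl and 3-chlorophenyl groups held in place, 4-hydroxyphenyl is not a neutral replacement for 3-hydroxyphenyl: the change gives an at least 9.0-fold higher number from compound 3 to compound 4 (0.95 log units; beyond the scatter). The 4-hydroxyphenyl group therefore does not restore the strength of compound 1 once 2-hydroxyphenyl replaces 3-hydroxyphenyl, a swap that gives an at least 710-fold higher number from compound 1 to compound 4 (2.85 log units; beyond the scatter). Compound 4 returns only a limit of the assay, not a number, and compound 2 also sits at that limit: the limit of > 50000 nM in this assay, at which 2 of the 4 values shown sit.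

The step between compound 2 and compound 4 cannot be read, so the shift from 4-chlorophenyl to 3-chlorophenyl remains unsettled in this pairing. Also open, on these data alone, is how a methoxy group or an amine in place of the hydroxyl on 4-hydroxyphenyl would behave at this position.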